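Acetyl in Place of (2-Hydroxyethoxy)methyl on the Shared Core

The source may hold more compounds than are shown below. What is called first, only, known or untested is meant among the compounds shown, and "the series" means these compounds.

Compound 1 `Nc1nn(COCCO)c2nnc(-c3ccccc3)c(-c3ccccc3)c12` was tested in a functional assay on HT-29 cells (Homo sapiens) for cytotoxicity; on this read-out higher numbers stand for weaker inhibition and lower numbers for stronger inhibition. In this assay compound 1 gives only a limit of the assay, > 100000 nM. Compound 2 `CCNC(=O)Nc1[nH]nc2nnc(-c3ccccc3)c(-c3ccccc3)c12` likewise gives only a limit in this assay, > 100000 nM. Both results sit at the limit of > 100000 nM in this assay, at which 2 of the 2 values shown sit, so compound 1 stands at the limit and nowhere else on the numbers shown. Compound 3 `CC(=O)n1nc(N)c2c(-c3ccccc3)c(-c3ccccc3)nnc21` is not yet measured; it differs from compound 1 by acetyl in place of (2-hydroxyethoxy)methyl on an aromatic nitrogen. Among the compounds with values here, no step between measured compounds is known, so compound 3 is expected to show no change beyond the usual scatter, an expected step of a number no higher from compound 1 to compound 3 (the limit leaves the size open). Compound 3 is estimated at 100000 nM, in the range 30000 nM to 300000 nM.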

Compound 3, half-maximal inhibitory concentration: > 100000 nM
Compound 3 gave a limit, no number; the forecaster's own chance of this, stated with the estimate: 75%; the middle value sits exactly at the limit.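

Compound 1 and compound 3 both stop at a limit in this assay, so no step can be read between them: the limit of > 100000 nM in this assay, at which 3 of the 3 values shown sit.

The compounds shown leave open whether any change on the shared core would give a number rather than a limit in this assay.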